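From Methoxy to Carboxymethyl: an Expected Outcome for Compound 3

The source may hold more compounds than are shown below. What is called first, only, known or untested is meant among the compounds shown, and "the series" means these compounds.

Compound 1 `COc1ccc(-c2cnn(C)c2NC(=O)O[C@H](C)c2ccccc2)cc1` was tested in an in vitro functional assay on chem-1 cells for antagonist activity at lysophosphatidic acid receptor 3 (Homo sapiens), read by FLIPR and calcium flux, with stated times of 30 min and 100 s (on this read-out higher numbers stand for weaker inhibition and lower numbers for stronger inhibition), and gave only a limit, > 30000 nM, rather than a number. Compound 2 `CC(OC(=O)Nc1c(-c2ccc(F)cc2)cnn1C)c1ccccc1Cl`, a second member of the same series, likewise reached only a limit in this assay, > 30000 nM. Going by the values given here, compound 1 therefore stands at the edge of what this measurement can resolve, and the one other value shown sits at the same edge: the limit of > 30000 nM in this assay, at which 2 of the 2 values shown sit. Among the compounds with values here, no step between the two measured compounds can be counted, since they differ in more than one place, so all that their values show is that neither is resolved as an inhibitor.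

Compound 3 `C[C@@H](OC(=O)Nc1c(-c2ccc(CC(=O)O)cc2)cnn1C)c1ccccc1` has not yet been measured in this assay. It differs from compound 1 in a single place: carboxymethyl in place of methoxy on an aromatic carbon. Within the data shown here, with both measured compounds resting at the limit, there is no measured step to draw on, and the expected step from compound 1 to compound 3 is an at least 1.2-fold lower number from compound 1 to compound 3 (0.07 log units; that floor lies within the scatter), which is not expected to exceed the usual scatter in either direction. Compound 3 is accordingly expected to give about 25000 nM in this assay, within a range from 5000 nM to 60000 nM, most probably again as a limit rather than a number.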

Compound 3, half-maximal inhibitory concentration: > 30000 nM
Compound 3 was reported as a limit (the forecaster's own chance of this, stated with the estimate: 70%); middle value at least 1.2-fold (0.07 log units) from the limit.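

In this assay compound 3 gives > 30000 nM, which is a limit and not a number. Going by these compounds alone, compound 1 also rests at a limit, so no step from compound 1 to compound 3 can be read: the limit of > 30000 nM in this assay, at which 3 of the 3 values shown sit. The compounds shown leave open whether carboxymethyl in place of methoxy on an aromatic carbon alters inhibition at all.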